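The source may report more compounds than this note shows. Statements on the series, on what has been measured and on what is new or still open speak of the compounds shown alone.

Compound 1 `Cc1ccc(CNc2cc(C(F)(F)F)cc3[nH]ncc23)c([N+](=O)O)c1`: 37400 nM
Compound 2 `FC(F)(F)c1cc(NC[C@@H]2CCCCN2)c2cn[nH]c2c1`: > 20000 nM

Among the compounds with values here, in a functional assay on B16 cells (Mus musculus) for inhibition, read by MTT assay, with a stated time of 24 h (on this read-out lower numbers stand for stronger inhibition and higher numbers for weaker inhibition), compound 1 gives 37400 nM, the only actual number so far. Compound 2 is recorded at > 20000 nM, which is a limit of the assay and not a number. The two compounds therefore cannot be ranked against each other.

Compound 3 `CS(=O)(=O)c1ccc(CNc2cc(C(F)(F)F)cc3[nH]ncc23)c([N+](=O)O)c1` keeps the core of compound 1 but has methylsulfonyl in place of methyl on an aromatic carbon. Within the data shown here, no measured pair shows what this change does. In this assay the expectation is therefore no step beyond the scatter, in either direction. That expectation rests only on compound 1 at 37400 nM. The estimated step is a 1.1-fold lower number from compound 1 to compound 3 (0.03 log units; within the scatter). Compound 3 is expected at 35000 nM. Its estimated range runs from 12000 nM to 100000 nM.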

Compound 3, half-maximal inhibitory concentration: > 20000 nM
Compound 3 gave a limit, no number; the forecaster's own chance of this, stated with the estimate: 30%; the middle value is on the limit's open side.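

No step can be read from compound 1 to compound 3, since compound 3 gave a limit of the assay and not a number: the limit of > 20000 nM in this assay, at which 2 of the 3 values shown sit.

The compounds shown leave open what methylsulfonyl in place of methyl on an aromatic carbon does in this assay.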